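The source may report more compounds than this note shows. Statements on the series, on what has been measured and on what is new or still open speak of the compounds shown alone.

For the measured compounds named here, in a functional assay on K562 cells (Homo sapiens) for cytotoxicity, read by trypan blue exclusion, with a stated time of 96 h (a higher number here means a weaker inhibitor, a lower number a stronger inhibitor), compound 2 `COc1cc(OC)c(/C=C/S(=O)(=O)Cc2ccc(OC)c(NCCC(=O)O)c2)c(OC)c1` stands at 5000 nM, the higher of the two numbers so far, and compound 1 `COC(=O)C(Nc1cc(CS(=O)(=O)/C=C/c2c(OC)cc(OC)cc2OC)ccc1OC)c1ccc(F)cc1` gives 800 nM. Compound 3 `COc1cc(OC)c(/C=C/S(=O)(=O)Cc2ccc(OC)c(NC(F)(F)C(=O)O)c2)c(OC)c1` is not yet measured and differs from compound 2 as follows: carboxy(difluoro)methyl in place of 2-carboxyethyl on a nitrogen on an aromatic ring. In short, carboxy(difluoro)methyl replaces 2-carboxyethyl on a nitrogen on an aromatic ring. Going by the values given here, one measured step bears on this, at the same nitrogen: a 6.3-fold higher number from compound 1 to compound 2 (0.80 log units; beyond the scatter), a modest change beyond the scatter. Among the compounds with values here, it shows that the group on that nitrogen can move the number, but no measured compound carries carboxy(difluoro)methyl, so the direction is poorly fixed. A step of similar or smaller size toward a lower number is expected in this assay, and a result within the scatter remains possible. The expected change is a 3.3-fold lower number from compound 2 to compound 3 (0.52 log units; beyond the scatter). The estimated value for compound 3 is 1500 nM, with an expected range from 250 nM to 7000 nM.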

Compound 3, half-maximal inhibitory concentration: 150 nM
The estimate for compound 3 lay 10-fold (1.00 log units) above the measured number, and the stated range ends above it.
By their numbers in this assay, from the lowest: compound 3; then compound 1; then compound 2.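

In this assay, the step of a 33-fold lower number from compound 2 to compound 3 (1.52 log units; beyond the scatter) shows that this nitrogen on an aromatic ring can carry a small group without a ring and still give the lowest number of the three compounds. The step of a 5.3-fold lower number from compound 1 to compound 3 (0.73 log units; beyond the scatter) shows that the (4-fluorophenyl)(methoxycarbonyl)methyl group, with its aromatic ring, is not needed to reach that level, while compound 1 stands between the two carboxy-bearing compounds, so the presence of a carboxy group alone does not set the order. No available evidence explains the gain.

The change shortens the chain and adds the two fluorines together, so the contribution of each remains unresolved. Plain carboxymethyl would separate them, and the methyl ester of carboxy(difluoro)methyl would test the need for the free carboxylic acid.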